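This account rests on a few compounds, and the source may have more. Where it says the series, first, only, none or still open, it means among the compounds named here.

Of the compounds shown here, three built on a shared core have so far been measured in a physicochemical assay for lipophilicity, at pH 7.4; on this read-out lower numbers stand for lower lipophilicity and higher numbers for higher lipophilicity. Compound 1 `Cc1cc(C(=O)Nc2c(F)cccc2F)nn1Cc1cc(Cl)ccc1OCc1ccccc1` gives 3.7 and stands highest of the three numbers. Compound 2 `Cc1cc(NC(=O)C2CCCC2)nn1Cc1cc(Cl)ccc1OCc1ccccc1` gives 3.5 and is the nearest to it; the step of a number 0.20 log units lower from compound 1 to compound 2 (within the scatter) lies within the scatter. Compound 3 `Cc1cc(NC(=O)OCc2ccccc2)nn1Cc1cc(Cl)ccc1OCc1ccccc1` gives 3.1 and is the furthest from compound 1; the step of a number 0.60 log units lower from compound 1 to compound 3 (beyond the scatter) lies beyond the scatter. The step of a number 0.40 log units lower from compound 2 to compound 3 (beyond the scatter) also lies beyond the scatter.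

Compound 4 `Cc1cc(NC(=O)OCC(C)C)nn1Cc1cc(Cl)ccc1OCc1ccccc1` has not yet been measured in this assay. It differs from compound 1 in one place: (isobutoxycarbonyl)amino in place of (2,6-difluorophenyl)carbamoyl on an aromatic carbon. For the measured compounds named here, two measured steps bear on this change, since each of them also removes (2,6-difluorophenyl)carbamoyl from the same aromatic carbon: a number 0.20 log units lower from compound 1 to compound 2 (within the scatter) and a number 0.60 log units lower from compound 1 to compound 3 (beyond the scatter). Of these, the step to compound 3, in which (benzyloxycarbonyl)amino enters, is the closer match to the change in compound 4, and it was modest and downward. A modest downward step is therefore expected in this assay as well, namely a number 0.70 log units lower from compound 1 to compound 4 (beyond the scatter). Compound 4 is accordingly estimated at 3, with a range from 2.5 to 3.5.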

Compound 4, distribution coefficient: 3.3
Beside the measured number, compound 4's estimate is 0.30 log units below it; the measured number falls inside the stated range.
By their numbers in this assay, from the lowest: compounds 3, 4, 2 and 1 (each within the scatter of the next, the first and the last beyond it).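

In this assay, (isobutoxycarbonyl)amino, which has no ring, takes the place of (2,6-difluorophenyl)carbamoyl on the aromatic carbon and gives a step beyond the scatter (a number 0.40 log units lower from compound 1 to compound 4 (beyond the scatter)), so a step of this kind does not need the phenyl ring that compound 3 carries, although compound 2 stays within the scatter of compound 1. On the carbamate itself, isopropyl in place of phenyl makes no difference that can be told from the scatter (a number 0.20 log units higher from compound 3 to compound 4 (within the scatter)), and the same holds for isobutoxy in place of cyclopentyl on the carbonyl carbon (a number 0.20 log units lower from compound 2 to compound 4 (within the scatter)), which places compound 4 within the scatter of two compounds that are themselves set apart beyond it. Nothing measured alongside these numbers accounts for them.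

The compounds shown leave open how a simple amine or a carboxylic acid on the same aromatic carbon would read in this series. They also leave open whether a longer chain or a methoxy group on the carbamate oxygen would separate from compound 3 and compound 4 by more than the scatter.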